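The source may report more compounds than this note shows. Statements on the series, on what has been measured and on what is new or still open speak of the compounds shown alone.

Working notes on the series. Three compounds carry an entry in a toxicity assay on NIH3T3 cells (Mus musculus) for cytotoxicity, read by resazurin assay; on this read-out lower numbers stand for an effect already at smaller amounts and higher numbers for an effect only at larger amounts of compound. Compound 1, `O=C(c1ccc(NCc2cncn2Cc2ccc(-c3ccccc3)cc2)cc1-c1ccccc1)N1CCCCC1`, is reported in this assay at > 1000 nM, which is a limit of the assay and not a number. Compound 3, `Cc1ccccc1-c1cc(NCc2cncn2Cc2ccc(-c3ccccc3)cc2)ccc1-c1nc2ccccc2s1`, is reported in this assay at > 1000 nM, again a limit rather than a number. Compound 2, `COC(=O)c1ccc(NCc2cncn2Cc2ccccc2OC)cc1-c1ccccc1`, has in this assay "not determined" (no result reported), so no single number says where it stands; the two further values shown sit at the limit of > 1000 nM in this assay, at which 2 of the 3 values shown sit. Among the measured compounds shown here, no step between measured compounds that differ in one place is available, so nothing measured here tells how a change of this kind moves the read-out.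

Compound 4, `COC(=O)c1ccc(NCc2cncn2Cc2ccc(Br)cc2)cc1-c1ccccc1`, differs from compound 2 in one place: 4-bromophenyl in place of 2-methoxyphenyl on a saturated chain carbon bound to an aromatic nitrogen. For the measured compounds named here, with no measured step to lean on, the expected size of the step in this assay is none beyond the scatter, in no particular direction, and the expectation rests on the readings of compound 1 and compound 3 being limits. Compound 4 is therefore expected to come out at about 3000 nM, within a range from 800 nM to 20000 nM, and the report is expected most likely to be a limit alone.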

Compound 4, half-maximal effective concentration: > 10000 nM
Compound 4 was reported as a limit; the forecaster's own chance of this, stated with the estimate: 75%; middle value at least 3.3-fold (0.52 log units) away from the limit.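

Among the compounds shown here, no step from compound 2 to compound 4 can be read in this assay, as compound 2 has no number to start from. Compound 4 gives > 10000 nM, which is a limit and not a number. The compounds shown leave open how 4-bromophenyl in place of 2-methoxyphenyl moves this read-out, and none of them has a single number here.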